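This account rests on a few compounds, and the source may have more. Where it says the series, first, only, none or still open, it means among the compounds named here.

The series is built on one shared core that carries an amidine linked to a benzyl group. Compound 1 `N=C(NCc1ccc(O)cc1)[C@@H]1CCC(=O)N1Cc1ccccc1[N+](=O)[O-]` is the starting point; in a functional assay on SH-SY5Y cells (Homo sapiens) for cytotoxicity, read by MTT assay, with stated times of 8 h, 30 min and 12 h, tested at 5 uM (a lower number here means a weaker effect, a higher number a stronger effect of the compound at the concentration tested), compound 1 gives 30.4%. Compound 2 `COc1ccc(CNC(=N)[C@@H]2CCC(=O)N2Cc2ccccc2[N+](=O)[O-])cc1` differs from compound 1 by methyl in place of hydrogen on an oxygen on an aromatic ring, and in this assay compound 2 gives 25.4%, a step of a number 5 percentage points lower from compound 1 to compound 2 (within the scatter). Compound 3 `N=C(NCc1ccc(O)cc1)[C@@H]1CCC(=O)N1Cc1ccc(F)cc1` keeps the hydroxy group but alters the core, the difference being (4-fluorophenyl in place of 2-nitrophenyl on a saturated chain carbon bound to an amide-type nitrogen in a ring); in this assay compound 3 gives 48.6%, a step of a number 18.2 percentage points higher from compound 1 to compound 3 (beyond the scatter), which places compound 3 above both compound 1 and compound 2.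

Compound 4 `COc1ccc(CNC(=N)[C@@H]2CCC(=O)N2Cc2ccc(F)cc2)cc1` has not yet been measured. It differs from compound 3 by methyl in place of hydrogen on an oxygen on an aromatic ring, which is the same change, at the same place, as that from compound 1 to compound 2. The step from compound 3 to compound 4 is expected to be a number 4.6 percentage points lower from compound 3 to compound 4 (within the scatter) because the same change earlier gave a number 5 percentage points lower from compound 1 to compound 2 (within the scatter). Compound 4 is therefore expected to give about 44%, with an estimated range from 30% to 58%.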

Compound 4, a percentage reported as activity, at one concentration (the size of the read-out at that concentration, not a potency): 38.1%
For compound 4 the middle estimate is 5.9 percentage points above the measured one, and the stated range covers the measured number.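

In this assay, among the compounds shown here, the change from hydroxy to methoxy gives a number 10.5 percentage points lower from compound 3 to compound 4 (beyond the scatter), which has the same direction as on the core of compound 1 and a size that cannot be told apart from the earlier step: the same change on two cores in this assay, a number 5 percentage points lower (within the scatter) from compound 1 to compound 2 and a number 10.5 percentage points lower (beyond the scatter) from compound 3 to compound 4, 5.5 percentage points apart, within the scatter of two such steps The exchange of 2-nitrophenyl for 4-fluorophenyl, now also seen on the methoxy side, gives a number 12.7 percentage points higher from compound 2 to compound 4 (beyond the scatter), and it too carries over: the same change on two cores in this assay, a number 18.2 percentage points higher (beyond the scatter) from compound 1 to compound 3 and a number 12.7 percentage points higher (beyond the scatter) from compound 2 to compound 4, 5.5 percentage points apart, within the scatter of two such steps Within these four compounds, each change therefore acts much the same whichever form the other place takes, but this rests on only two pairs per change and shows neither that the agreement extends to other cores nor why either change shifts the read-out.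

The compounds shown leave open whether an ethyl group or a longer chain on that oxygen, or an amine or a carboxylic acid in place of the hydroxy, would follow the same course. With one concentration tested, they show only a stronger or weaker effect at that concentration.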